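Hydrogen in place of phenyl: compound 3

This account rests on a few compounds, and the source may have more. Where it says the series, first, only, none or still open, it means among the compounds named here.

Two compounds of the shared core have numbers in a functional assay on BXPC-3 cells (Homo sapiens) for inhibition, read by MTT assay, with a stated time of 72 h; on this read-out higher numbers stand for weaker inhibition of growth and lower numbers for stronger inhibition of growth. Compound 1 `O=S(=O)(NCCCNCc1ccc(Cl)cc1)c1cc(C(F)(F)F)cc(C(F)(F)F)c1` gives 1600 nM. Compound 2 `O=S(=O)(NCCCNCc1ccc(-c2ccccc2)cc1)c1cc(C(F)(F)F)cc(C(F)(F)F)c1` gives 1700 nM and so stands highest of the two numbers, with compound 1 as its nearest neighbour at a gap within the scatter. Within the data shown here, the one measured step, a 1.1-fold higher number from compound 1 to compound 2 (0.03 log units; within the scatter), shows that phenyl in place of chloro on an aromatic carbon left the concentration for half-maximal growth inhibition essentially where it was. Compound 3 `O=S(=O)(NCCCNCc1ccccc1)c1cc(C(F)(F)F)cc(C(F)(F)F)c1` carries neither group: hydrogen in place of phenyl on an aromatic carbon. Among the measured compounds shown here, no measured step covers loss of a group to hydrogen at this place, so the only bearing comes from compound 1 and compound 2, whose numbers sit within the scatter of each other. The expectation is therefore no step beyond the scatter, no change at the digits printed from compound 2 to compound 3 (within the scatter). Compound 3 is estimated at 1700 nM, in the range 700 nM to 4500 nM.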

Compound 3, concentration for 50% growth inhibition: 13000 nM
Compound 3: middle estimate off by 7.6-fold (0.88 log units), on the low side; measured number above the stated range.
By their numbers in this assay, from the lowest: compounds 1 and 2 (each within the scatter of the next); then compound 3.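

In this assay, the aromatic carbon para to a large group proves sensitive to the loss of its substituent, with a 7.6-fold higher number from compound 2 to compound 3 (0.88 log units; beyond the scatter) for hydrogen in place of phenyl and an 8.1-fold higher number from compound 1 to compound 3 (0.91 log units; beyond the scatter) for hydrogen in place of chloro. The match between compound 1 and compound 2 therefore does not extend to the unsubstituted ring: among these three compounds, both substituted members give lower numbers than compound 3, while chloro and phenyl cannot be told apart. No measurement bearing on the reason for this step is available.

As far as these compounds go, it remains open whether a fluoro, methoxy or amine group at this place would keep the number near those of compound 1 and compound 2 or move it towards that of compound 3. A carboxylic acid here, or a longer chain, also remains untested within this set, and no group shown gives a number below those of compound 1 and compound 2.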